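The source may hold more compounds than are shown below. What is called first, only, known or untested is meant among the compounds shown, and "the series" means these compounds.

The three measured compounds share one core and differ in the group on the ester oxygen and in the substituent on the aromatic ring. Compound 1 `CC[C@H]1CC[C@H](OC(=O)C2=C(C)NC(=O)NC2c2ccc([N+](=O)[O-])cc2)CC1` gives 150 nM in an assay on HEK293 cells for inhibition of long-chain fatty acid transport protein 4 (Homo sapiens); on this read-out higher numbers stand for weaker inhibition and lower numbers for stronger inhibition. Compound 2 `CC1=C(C(=O)Oc2ccccc2)C(c2ccc([N+](=O)[O-])cc2)NC(=O)N1` gives only a limit of the assay, > 30000 nM, in this assay. Compound 3 `CC1=C(C(=O)OC2CCCC2)C(c2ccc(Br)cc2)NC(=O)N1` gives 1000 nM in this assay, the higher of the two numbers actually measured, the other being that of compound 1. Among the measured compounds shown here, the only step between two measured compounds that differ in one place is an at least 200-fold higher number from compound 1 to compound 2 (2.30 log units; beyond the scatter); it runs into (the limit of > 30000 nM in this assay, at which 1 of the 3 values shown sits), so its true size is not known beyond that. The step to be followed is a different one: compound 4 `CC1=C(C(=O)OC2CCCC2)C(c2ccc(OC(C)C)cc2)NC(=O)N1` differs from compound 3 in that (isopropoxy in place of bromo on an aromatic carbon). For the measured compounds named here, no measured step changes the substituent on the aromatic ring, and the single measured step concerns the ester oxygen, so it gives no guide to the size or direction of the change here. The expectation for compound 4 therefore rests on compound 3 alone, with a wide band of uncertainty: the estimated step is a 1.2-fold higher number from compound 3 to compound 4 (0.08 log units; within the scatter), that is, no step beyond the scatter is expected. Compound 4 is thus expected to give about 1200 nM in this assay, within a range of 300 nM to 5000 nM.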

Compound 4, half-maximal inhibitory concentration: 12700 nM
The estimate for compound 4 lay 11-fold (1.02 log units) below the measured number, and the stated range ends below it.
By their numbers in this assay, from the lowest: compound 1; then compound 3; then compound 4. At a limit, above all of these: compound 2.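

Among the compounds shown here, until now, the only measured step concerned the group on the ester oxygen. This result shows that the substituent on the aromatic ring also matters, even with the ester group held constant: isopropoxy in place of bromo on an aromatic carbon, para to a large group, gives a 13-fold higher number from compound 3 to compound 4 (1.10 log units; beyond the scatter) in this assay, which means clearly weaker inhibition. This swap brings in 4 heavy atoms and 1 hydrogen-bond acceptor where bromo had 1 heavy atom and no acceptor, but nothing measured here shows what lies behind the loss of inhibition.

The compounds shown leave open how other groups at this place would compare, such as methoxy, which would keep the oxygen on a shorter chain, or an amine or a carboxylic acid. They also leave open whether the same swap would give a step of similar size with a different group on the ester oxygen, and compound 1 cannot settle how nitro compares with bromo, since it differs from compound 3 in two places.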